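Changing the Group on the Carbonyl Carbon

The source may hold more compounds than are shown below. What is called first, only, known or untested is meant among the compounds shown, and "the series" means these compounds.

Three compounds sharing one core were measured in a functional assay on PC-3 cells (Homo sapiens) for inhibition, read by CellTiter-Glo, with a stated time of 72 h; a lower number here means that less compound is tolerated, a higher number that more compound is tolerated:

compound 1, `CC1=C(C(C)C(=O)N(C)CCN(C)C)c2cc(F)ccc2/C1=C\c1ccc([S+](C)[O-])cc1`, gives 44600 nM
compound 2, `CC1=C(C(C)C(=O)N(CCNC(C)C)C(C)C)c2cc(F)ccc2/C1=C\c1ccc([S+](C)[O-])cc1`, gives 15200 nM
compound 3, `CC1=C(C(C)C(=O)NCCN2CCCCC2)c2cc(F)ccc2/C1=C\c1ccc([S+](C)[O-])cc1`, gives 36300 nM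

Compound 3 stands second highest of the three numbers. Its nearest neighbour is compound 1, and the step of a 1.2-fold lower number from compound 1 to compound 3 (0.09 log units; within the scatter) lies within the scatter, so the two cannot be ordered. The step of a 2.4-fold higher number from compound 2 to compound 3 (0.38 log units; beyond the scatter) is beyond the scatter but modest, as is a 2.9-fold lower number from compound 1 to compound 2 (0.47 log units; beyond the scatter).

Compound 4, `CC1=C(C(C)C(=O)N2CCN(CCN(C)C)CC2)c2cc(F)ccc2/C1=C\c1ccc([S+](C)[O-])cc1`, differs from compound 3 in one place: 4-(2-(dimethylamino)ethyl)piperazin-1-yl in place of (2-(piperidin-1-yl)ethyl)amino on a carbonyl carbon. Among the compounds with values here, no measured step repeats this exact change; the three steps in this assay, all at the same carbonyl carbon, span only modest sizes. Compound 4 is therefore expected to stay close to compound 3, with the step of a 1.0-fold lower number from compound 3 to compound 4 (0.02 log units; within the scatter) expected to fall within or just beyond the scatter in either direction. The estimate for compound 4 is 35000 nM, with a range from 12000 nM to 100000 nM.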

Compound 4, half-maximal cytotoxic concentration: 50000 nM
Beside the measured number, compound 4's estimate is 1.4-fold (0.15 log units) below it, within the range that was stated.
By their numbers in this assay, from the lowest: compound 2; then compounds 3, 1 and 4 (each within the scatter of the next).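

In this assay the carbonyl carbon takes a bulkier group that carries a second ring hetero atom and drops the hydrogen-bond donors from 1 to 0, yet a 1.4-fold higher number from compound 3 to compound 4 (0.14 log units; within the scatter) stays within the scatter, so this exchange has no readable effect on the number. The piperazine group also cannot be told apart from the open-chain (2-(dimethylamino)ethyl)(methyl)amino group, as a 1.1-fold higher number from compound 1 to compound 4 (0.05 log units; within the scatter) is within the scatter too. Only a 3.3-fold higher number from compound 2 to compound 4 (0.52 log units; beyond the scatter) goes beyond the scatter, and it is modest, so among these four compounds compound 2 alone stands apart, with the lowest number.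

As far as these compounds go, whether a carboxylic acid or a simple methylamino group on this carbonyl carbon would shift the number remains open. No measurement shown here explains why compound 2 differs from the other three.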